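Replacing Phenyl with a Pyrazole in Compound 2

The compounds below may be only part of what the source reports. "The series", "measured", "known", "first", "only" and "open" are said of these compounds alone.

Measured in an ADME assay on BaF3 cells (Mus musculus) for antiproliferative activity, read by CCK-8 assay, with a stated time of 72 h; a lower number here means a stronger inhibitor of growth, a higher number a weaker inhibitor of growth:
- compound 1 `O=C(CCSc1ccc2c(/C=C/c3ccccn3)n[nH]c2c1)Nc1cccc(C(F)(F)F)c1`: 2300 nM
- compound 2 `CN1CCN(Cc2ccc(NC(=O)CCSc3ccc4c(-c5ccccc5)n[nH]c4c3)cc2C(F)(F)F)CC1`: 600 nM

Of the two measured compounds, compound 2 has the lower number, at 600 nM. Compound 1 reads 2300 nM, and this gap lies beyond the usual scatter. The two compounds differ in more than one place, so their values alone do not isolate any single structural feature.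

The next compound, compound 3 `CN1CCN(Cc2ccc(NC(=O)CCSc3ccc4c(-c5cnn(C)c5)n[nH]c4c3)cc2C(F)(F)F)CC1`, keeps compound 2 intact except for one group: 1-methyl-1H-pyrazol-4-yl stands in place of phenyl on an aromatic carbon of a five-membered aromatic ring with 2 nitrogen, part of a fused or bridged system of two rings. The counted difference is 1-methyl-1H-pyrazol-4-yl in place of phenyl on an aromatic carbon.

Going by the values given here, no measured pair shows this exchange, so the expectation rests only on the value of compound 2 at 600 nM and remains uncertain. A modest move toward stronger growth inhibition in this assay is expected, a 2.0-fold lower number from compound 2 to compound 3 (0.30 log units; within the scatter). For compound 3 the estimated value is 300 nM, with an expected range of 60 nM to 1500 nM.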

Compound 3, concentration for 50% growth inhibition: 1400 nM
The estimate for compound 3 lay 4.7-fold (0.67 log units) below the measured number, within the range that was stated.
By their numbers in this assay, from the lowest: compound 2; then compounds 3 and 1 (each within the scatter of the next).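

In this assay, going by these compounds alone, the exchange of phenyl for 1-methyl-1H-pyrazol-4-yl gives a 2.3-fold higher number from compound 2 to compound 3 (0.37 log units; beyond the scatter) and this is the first single-place comparison at this position. It shows that the value responds to the group on this aromatic carbon, and in this one pair phenyl gives the stronger growth inhibition. The two groups have the same count of heavy atoms, but the entering five-membered ring contains two nitrogen atoms and two hydrogen-bond acceptors where phenyl has none, so the loss does not follow from a change in the number of heavy atoms, and this one step cannot separate the remaining differences between the rings. Nothing available accounts for the direction or size of this step.

The compounds shown leave open whether the change follows from the ring itself or from its methyl group, which a pyrazol-4-yl group without that methyl or a pyridin-3-yl group could help to separate. They also leave open whether a phenyl ring carrying a methoxy group or a fluorine atom at this position would read differently from compound 2.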